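Replacing the styryl amide in a norepinephrine transporter series

The source may hold more compounds than are shown below. What is called first, only, known or untested is meant among the compounds shown, and "the series" means these compounds.

Compound 1 `CN1CC[C@@H](c2ccc(Cl)cc2)[C@H](C(=O)NCc2ccc(CNC(=O)/C=C/c3ccc(Cl)cc3)cc2)C1` and compound 2 `CN1CC[C@@H](c2ccc(Cl)cc2)[C@H](C(=O)NCc2ccc(CNC(=O)[C@@H]3CN(C)CC[C@H]3c3ccc(Cl)cc3)cc2)C1` were tested in an assay on a subcellular fraction from brain for inhibition of Norepinephrine transporter (Rattus norvegicus); on this read-out higher numbers stand for weaker inhibition and lower numbers for stronger inhibition. In this assay compound 1 reaches only > 2000 nM, which is a limit of the assay and not a number. Compound 1 thus sits at the limit of > 2000 nM in this assay, at which 1 of the 2 values shown sits. Compound 2 gives 74 nM in this assay. Compound 3 `CN1CC[C@@H](c2ccc(Cl)cc2)[C@H](C(=O)NCc2ccc(CNC(=O)c3cccc(C(F)(F)F)c3)cc2)C1` carries 3-(trifluoromethyl)phenyl in place of 2-(4-chlorophenyl)ethenyl on a carbonyl carbon. Within the data shown here, with no measured step of this kind to go by, the move in this assay is expected to be small, a step that the limit leaves unreadable from compound 1 to compound 3. Compound 3 is estimated at 3000 nM, within 800 nM to 15000 nM.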

Compound 3, inhibition constant: 508 nM
For compound 3 the middle estimate is 5.9-fold (0.77 log units) above the measured one, outside the stated range (below it).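

In this assay, 3-(trifluoromethyl)phenyl in place of 2-(4-chlorophenyl)ethenyl on a carbonyl carbon gives an at least 3.9-fold lower number from compound 1 to compound 3 (0.59 log units; beyond the scatter). This shows that the group at this position changes the read-out, and that a double bond outside aromatic rings is not needed for a value within the range of the assay. The value of compound 1 is a limit and not a number, so the step gives only a minimum size: the limit of > 2000 nM in this assay, at which 1 of the 3 values shown sits.

As far as these compounds go, it remains open whether the trifluoromethyl group itself contributes to this step, which an unsubstituted phenyl on the same carbonyl carbon would show. From the compounds shown here alone, it also remains open how a saturated 2-(4-chlorophenyl)ethyl chain would compare.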